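Isopropyl on the amide nitrogen of compound 2

The compounds below may be only part of what the source reports. "The series", "measured", "known", "first", "only" and "open" are said of these compounds alone.

In an ADME assay on microsomes from liver (Rattus norvegicus) for metabolic stability (a higher number here means that the compound lasts longer, a lower number that the compound disappears faster), compound 1 `CC(C)C(c1ccc(-c2ccc3cccc(F)c3c2)[nH]c1=O)N1CCCCC1=O` gives 0.102 h. Compound 2 `CC(C)C(CC(N)=O)c1ccc(-c2ccc3cccc(F)c3c2)[nH]c1=O` gives < 0.0667 h, which is a limit of the assay and not a number. This is the limit of < 0.0667 h in this assay, at which 1 of the 2 values shown sits. Compound 3 `CC(C)NC(=O)CC(c1ccc(-c2ccc3cccc(F)c3c2)[nH]c1=O)C(C)C` differs from compound 2 by isopropyl in place of hydrogen on an amide-type nitrogen, which turns carbamoylmethyl into (isopropylcarbamoyl)methyl. Among the measured compounds shown here, the one measured step that bears on this is an at least 1.5-fold lower number from compound 1 to compound 2 (0.18 log units; that floor lies within the scatter). That step exchanges 2-oxopiperidin-1-yl for carbamoylmethyl on a saturated chain carbon, so it is not the same change and gives no size for the new isopropyl. No shift beyond the scatter can be argued from it in this assay, in either direction. The expected step is a step that the limit leaves unreadable from compound 2 to compound 3, with none expected beyond the scatter. Compound 3 is estimated at 0.065 h, with an expected range from 0.04 h to 0.14 h.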

Compound 3, half-life: < 0.0667 h
Compound 3 was reported as a limit; the forecaster's own chance of this, stated with the estimate: 55%; the middle value does not contradict the limit.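

With isopropyl in place of the hydrogen on the amide-type nitrogen, compound 3, like compound 2, gives only a limit and not a number in this assay, so the step between these two compounds cannot be read and the isopropyl has no measurable size here. Exchanging 2-oxopiperidin-1-yl for (isopropylcarbamoyl)methyl gives an at least 1.5-fold lower number from compound 1 to compound 3 (0.18 log units; that floor lies within the scatter), so this position shows no shift beyond the scatter with either amide side chain. The read-out now offers little room for comparison at this position: the limit of < 0.0667 h in this assay, at which 2 of the 3 values shown sit.

Open, on these data alone, is whether a carboxylic acid or an amine in place of carbamoylmethyl would give a readable number in this assay. Also open, as far as these compounds go, is whether a longer chain on the amide-type nitrogen would separate from compound 2.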